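One group exchanged on the shared core

A few compounds are considered here, and "the series" means these few. Any claim that something is new, unique, unknown or untested is made for them only; others in the source may bear on it.

Measured in a functional assay on HepG2 cells (Homo sapiens) for antiproliferative activity, read by MTT assay, with a stated time of 72 h; a higher number here means a weaker inhibitor, a lower number a stronger inhibitor:
compound 1 `Cc1noc(C)c1-c1nn(Cc2ccc(C(=O)NC3CC3)cc2)c(=O)c2ccccc12`: > 100000 nM (a limit of the assay)
compound 2 `Cc1noc(C)c1-c1nn(Cc2ccc(C(=O)NC3CC(C)(C)N([O])C(C)(C)C3)cc2)c(=O)c2ccccc12`: 85100 nM
compound 3 `Cn1cc(Nc2nn(Cc3ccc(C(=O)NC4CCCCC4)cc3)c(=O)c3ccccc23)cn1`: 8300 nM

Of the numbers shown, compound 3 holds the lowest, and the gap to compound 2 at 85100 nM lies beyond the scatter. Compound 4 `Cc1noc(C)c1-c1nn(Cc2ccc(C(=O)NC3CCCCC3)cc2)c(=O)c2ccccc12` departs from compound 3 at a single place: 3,5-dimethyl-1,2-oxazol-4-yl in place of (1-methyl-1H-pyrazol-4-yl)amino on an aromatic carbon. There, 3,5-dimethyl-1,2-oxazol-4-yl stands on an aromatic carbon in place of (1-methyl-1H-pyrazol-4-yl)amino.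

Within the data shown here, no measured step covers this exchange directly. The only one available, an at least 1.1-fold lower number from compound 1 to compound 2 (0.07 log units; that floor lies within the scatter), concerns the group on an amide-type nitrogen, so it gives no size for this change. The indirect evidence comes from the two compounds that already carry the entering group, although each has a different group on that nitrogen. Compound 2 gives 85100 nM. Compound 1 gives > 100000 nM, which is a limit of the assay.

A move to a higher number in this assay is therefore expected, and the expected step is a 4.8-fold higher number from compound 3 to compound 4 (0.68 log units; beyond the scatter). For compound 4 the estimated value is 40000 nM, with an expected range of 12000 nM to 100000 nM.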

Compound 4, half-maximal inhibitory concentration: > 100000 nM
Compound 4: a limit, no number; the forecaster's own chance of this, stated with the estimate: 25%; middle value at least 2.5-fold (0.39 log units) from the limit.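

Among these compounds, with the cyclohexyl amide held fixed, 3,5-dimethyl-1,2-oxazol-4-yl in place of (1-methyl-1H-pyrazol-4-yl)amino gives an at least 12-fold higher number from compound 3 to compound 4 (1.08 log units; beyond the scatter) in this assay, the first direct reading of a change at this position. Going by these compounds, compound 4 gives > 100000 nM, which is a limit of the assay, so the step is a floor and its full size stays unknown: the limit of > 100000 nM in this assay, at which 2 of the 4 values shown sit. Among the compounds carrying 3,5-dimethyl-1,2-oxazol-4-yl, the change on the amide-type nitrogen gives an at least 1.1-fold higher number from compound 2 to compound 4 (0.07 log units; that floor lies within the scatter), and the remaining step, between two limits, cannot be read.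

The compounds shown do not separate the amino link from the pyrazole ring, so it remains open whether 1-methyl-1H-pyrazol-4-yl bonded directly to the aromatic carbon would behave like the leaving group. On these data alone, it is also open how a simple primary amine at this position would compare.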